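A few compounds are considered here, and "the series" means these few. Any claim that something is new, unique, unknown or untested is made for them only; others in the source may bear on it.

In a functional assay on PC-3 cells (Homo sapiens) for cytotoxicity, read by MTT assay, with a stated time of 48 h (on this read-out lower numbers stand for stronger inhibition and higher numbers for weaker inhibition), compound 1 `O=C(c1ccccc1)N1N=C(c2cc3ccccc3oc2=O)CC1c1ccccc1` gives 5870 nM; compound 2 `O=C(c1ccccc1Cl)N1N=C(c2cc3ccccc3oc2=O)CC1c1ccccc1` gives 6370 nM; compound 3 `Cc1ccc(S(=O)(=O)N2N=C(c3cc4ccccc4oc3=O)CC2c2ccccc2)cc1` gives 48600 nM.

Compound 3 stands highest of the three in this assay, beyond the scatter from both others, as an 8.3-fold higher number from compound 1 to compound 3 (0.92 log units; beyond the scatter) and a 7.6-fold higher number from compound 2 to compound 3 (0.88 log units; beyond the scatter) show, while a 1.1-fold higher number from compound 1 to compound 2 (0.04 log units; within the scatter) lies within it. Compound 4 `CNCC(=O)N1N=C(c2cc3ccccc3oc2=O)CC1c1ccccc1` carries ((methylamino)methyl)carbonyl in place of (4-methylphenyl)sulfonyl on an amine nitrogen in a ring. The two steps that bear on this change both exchanged a carbonyl-linked group for the sulfonyl group and raised the number by a modest amount; the step from compound 3 to compound 4 reverses that exchange, though with a ring-free acyl group in place of the aromatic ones. Compound 4 is therefore expected to give a lower number, with a 6.1-fold lower number from compound 3 to compound 4 (0.78 log units; beyond the scatter) as the estimated step. Compound 4 is expected at 8000 nM, in a range from 2500 nM to 25000 nM.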

Compound 4, half-maximal inhibitory concentration: 2300 nM
Compound 4: middle estimate off by 3.5-fold (0.54 log units), on the high side; the whole stated range lies above it.
By their numbers in this assay, from the lowest: compound 4; then compounds 1 and 2 (each within the scatter of the next); then compound 3.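

In this assay, the amine nitrogen in the ring accepts an acyl group without any ring: ((methylamino)methyl)carbonyl gives a 21-fold lower number from compound 3 to compound 4 (1.32 log units; beyond the scatter), which is more than a return to the aromatic amides, as a 2.6-fold lower number from compound 1 to compound 4 (0.41 log units; beyond the scatter) and a 2.8-fold lower number from compound 2 to compound 4 (0.44 log units; beyond the scatter) show. Among these compounds, then, an aromatic ring on the carbonyl carbon is not needed for the lowest number. Nothing measured here explains this gain.

From the compounds shown here alone, whether it follows from the methylamino nitrogen or from the loss of the aromatic ring stays open. An acetyl group, a dimethylamino group or a longer chain on the carbonyl carbon would separate the two.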